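This account rests on a few compounds, and the source may have more. Where it says the series, first, only, none or still open, it means among the compounds named here.

Of the compounds shown here, two have been tested so far in a functional assay on CCRF-CEM cells for agonist activity at C-X-C chemokine receptor type 4 (Homo sapiens), read by calcium flux, with a stated time of 25 min; on this read-out lower numbers stand for an effect already at smaller amounts and higher numbers for an effect only at larger amounts of compound. Compound 1 `c1cnc2c(c1)CCC[C@@H]2N(CC1CC1)C[C@H]1Cc2c(cccc2N2CCNCC2)CN1` gives > 30000 nM in this assay, which is a limit of the measurement rather than a number. Compound 2 `CN(C[C@H]1Cc2c(cccc2N2CCN(C3CC3)CC2)CN1)[C@H]1CCCc2cccnc21` likewise gives > 30000 nM in this assay, again a limit and not a number. For the measured compounds named here, compound 2 thus stands at the limit, and the limit of > 30000 nM in this assay, at which 2 of the 2 values shown sit, holds for both values shown, so no step between measured compounds can be drawn from them. Compound 3 `CN(C[C@H]1Cc2c(cccc2N2CCN3CCC[C@H]3C2)CN1)[C@H]1CCCc2cccnc21` has not yet been measured. It differs from compound 2 in one place: a group of 9 heavy atoms (7 carbon, 2 nitrogen; one five-membered non-aromatic ring with 1 hetero atom, one six-membered non-aromatic ring with 2 hetero atoms) in place of a group of 9 heavy atoms (7 carbon, 2 nitrogen; one three-membered non-aromatic ring of carbon only, one six-membered non-aromatic ring with 2 hetero atoms), on an aromatic carbon; the two have the same atoms, joined differently. Going by the values given here, with both measured values resting on the same limit, no measured step shows how far a change of this kind moves this assay, and the expectation for compound 3 rests on compound 2 alone. Compound 3 is therefore expected to sit at or near the same limit in this assay, the step of a number no higher from compound 2 to compound 3 (the limit leaves the size open) being estimated as none beyond the scatter. The estimate for compound 3 in this assay is 30000 nM, within a range from 10000 nM to 100000 nM.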

Compound 3, half-maximal effective concentration: > 30000 nM
Compound 3: no number, only a limit; the forecaster's own chance of this, stated with the estimate: 80%; the middle value lies on the limit itself.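

In this assay compound 3 gives > 30000 nM, which is a limit and not a number. Compound 2 and compound 3 thus both rest on a limit, and the step between them cannot be read: the limit of > 30000 nM in this assay, at which 3 of the 3 values shown sit.

The compounds shown leave open whether any change to the shared core can bring a measurable effect in this assay.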